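The source may report more compounds than this note shows. Statements on the series, on what has been measured and on what is new or still open speak of the compounds shown alone.

Measured compounds in a physicochemical assay for solubility, read by chemiluminescence, measured as kinetic solubility; on this read-out higher numbers stand for higher solubility and lower numbers for lower solubility:
Compound 1 `CC(=O)NCc1cccc(Cn2nc(NS(=O)(=O)c3ccc(Cl)s3)c3c(F)cccc32)c1`: in this assay compound 1 gives >= 139 ug/mL, which is a limit of the assay.
Compound 2 `CC(=O)NCc1cccc(Cn2nc(NS(=O)(=O)c3ccc(Cl)s3)c3c(CO)cccc32)c1`: in this assay compound 2 gives >= 113 ug/mL, which is a limit of the assay.

Compound 2 stands at a limit in this assay, so only a range is known for it (the limit of >= 113 ug/mL in this assay, at which 1 of the 2 values shown sits). Compound 1 likewise sits at a limit (the limit of >= 139 ug/mL in this assay, at which 1 of the 2 values shown sits). Among the compounds with values here, the one measured step, a step that the two limits leave unreadable from compound 1 to compound 2, is therefore of unreadable size. Compound 3 `CC(=O)NCc1cccc(Cn2nc(NS(=O)(=O)c3ccc(Cl)s3)c3c(C(C)=O)cccc32)c1` differs from compound 2 by acetyl in place of hydroxymethyl on an aromatic carbon. Within the data shown here, no measured step bears directly on this change, and the step from compound 1 to compound 2 supplies no size to lean on. The expectation for compound 3 is a value close to the limit at which compound 2 sits, and the expected step of an at least 1.1-fold lower number from compound 2 to compound 3 (0.05 log units; that floor lies within the scatter) is taken to lie within the scatter. Compound 3 is estimated at 100 ug/mL, in the range 40 ug/mL to 200 ug/mL.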

Compound 3, solubility: 57 ug/mL
Beside the measured number, compound 3's estimate is 1.8-fold (0.24 log units) above it; low and high end bracket the measured number.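

Acetyl in place of fluoro gives an at least 2.4-fold lower number from compound 1 to compound 3 (0.38 log units; beyond the scatter) in this assay, so the group on this aromatic carbon can move the read-out, which the two limits of the earlier compounds could not show. Acetyl in place of hydroxymethyl gives an at least 1.9-fold lower number from compound 2 to compound 3 (0.29 log units; that floor lies within the scatter), a floor that does not by itself separate the two groups beyond the scatter. Compound 2 remains at a limit, so the full size of that step stays unknown: the limit of >= 113 ug/mL in this assay, at which 1 of the 3 values shown sits.

As far as these compounds go, the step between compound 1 and compound 2 cannot be read, and the true values of both stay unknown. From the compounds shown here alone, whether an amine, a carboxylic acid or a longer chain on this aromatic carbon would give a number near that of compound 3 or reach a limit remains open.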